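A Small Positional Change on the Benzylidene Arm

A few compounds are considered here, and "the series" means these few. Any claim that something is new, unique, unknown or untested is made for them only; others in the source may bear on it.

Of the compounds shown here, three sharing one core have been tested in a functional assay on A549 cells (Homo sapiens) for inhibition, read by MTT assay, with a stated time of 72 h; on this read-out higher numbers stand for weaker inhibition and lower numbers for stronger inhibition. Compound 1 `CN(C(=O)NC(=O)c1c(F)cccc1F)c1nc(C(F)(F)F)c(C(=O)N/N=C/c2cc(C(F)(F)F)cc(C(F)(F)F)c2)s1` gives 17.3 ug/mL in this assay. Compound 2 `CN(C(=O)NC(=O)c1ccccc1F)c1nc(C(F)(F)F)c(C(=O)N/N=C/c2cccc(C(F)(F)F)c2)s1` gives 19.5 ug/mL. Compound 3 `CN(C(=O)NC(=O)c1c(F)cccc1F)c1nc(C(F)(F)F)c(C(=O)N/N=C/c2ccccc2C(F)(F)F)s1` gives 17.9 ug/mL. Among the measured compounds shown here, the three numbers lie close together: compound 3 is separated from compound 1 and from compound 2 by gaps that both fall inside the usual scatter of repeated measurements, so no order among them can be read from the data, and no single compound can be called stronger or weaker than the others.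

The next compound, compound 4 `CN(C(=O)NC(=O)c1c(F)cccc1F)c1nc(C(F)(F)F)c(C(=O)N/N=C/c2cccc(C(F)(F)F)c2)s1`, has not yet been measured in this assay. It differs from compound 3 in one place: 3-(trifluoromethyl)phenyl in place of 2-(trifluoromethyl)phenyl on a carbon with a double bond to nitrogen. Compound 2 already carries a 3-(trifluoromethyl)phenyl at the same position, with a different fluorinated benzoyl group on the other arm, and in this assay compound 2 gives 19.5 ug/mL, again inside the scatter of compound 3.

Given how flat the three measured numbers are, the step of a 1.0-fold higher number from compound 3 to compound 4 (0.00 log units; within the scatter) is expected to be none beyond the scatter, in no particular direction. Compound 4 is therefore estimated to give 18 ug/mL in this assay, with a likely range from 11 ug/mL to 30 ug/mL.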

Compound 4, half-maximal inhibitory concentration: 27.6 ug/mL
For compound 4 the middle estimate is 1.5-fold (0.19 log units) below the measured one; measured number inside the range.
By their numbers in this assay, from the lowest: compounds 1, 3, 2 and 4 (each within the scatter of the next).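

Among the compounds shown here, compound 4 ties the series together, since it differs in one place from each of the three earlier compounds, which shared no such step among themselves. In this assay, 3-(trifluoromethyl)phenyl in place of 2-(trifluoromethyl)phenyl on a carbon with a double bond to nitrogen gives (  a 1.5-fold higher number from compound 3 to compound 4 (0.19 log units; within the scatter)  ), fluoro in place of hydrogen on an aromatic carbon gives (  a 1.4-fold higher number from compound 2 to compound 4 (0.15 log units; within the scatter)  ), and hydrogen in place of trifluoromethyl on an aromatic carbon gives (  a 1.6-fold higher number from compound 1 to compound 4 (0.20 log units; within the scatter)  ), so none of these three single changes can be told apart from the scatter, including the change of place of the trifluoromethyl group on the phenyl ring. Nothing at hand offers a reason for these steps.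

Every compound shown carries trifluoromethyl on the phenyl ring attached to the carbon with a double bond to nitrogen, so it remains open whether an amine or a carboxylic acid on that ring would give a step beyond the scatter. Going by these compounds, it also remains open whether a plain phenyl, with no trifluoromethyl at all, would stay as close to these numbers.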